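The source may report more compounds than this note shows. Statements on the series, on what has been measured and on what is new or still open speak of the compounds shown alone.

Working notes on the dichlorophenyl-amine pair of cores.

Compound 1 `COc1ccc(/C=C/C(=O)Nc2cc3c(Nc4ccc(Cl)c(Cl)c4)ncnc3s2)cc1` and compound 2 `COc1ccc(/C=C/C(=O)Nc2cc3c(Nc4cc(Cl)cc(Cl)c4)ncnc3s2)cc1` share one core and differ only in the aryl group on the amine. Compound 3 `O=C(/C=C/c1ccccc1)Nc1cc2ncnc(Nc3cc(Cl)cc(Cl)c3)c2s1` carries the 3,5-dichlorophenyl of compound 2 on a second core; the difference between the two cores is not broken down here. Compound 4 `O=C(/C=C/c1ccccc1)Nc1cc2ncnc(Nc3ccc(Cl)c(Cl)c3)c2s1` is the counterpart of compound 3 on that second core and has not yet been measured.

In a functional assay on PC-3 cells (Homo sapiens) for antiproliferative activity, read by MTT assay, with a stated time of 48 h (on this read-out lower numbers stand for stronger inhibition and higher numbers for weaker inhibition), compound 1 gives 790 nM. In this assay compound 2 gives 450 nM. The change 3,4-dichlorophenyl in place of 3,5-dichlorophenyl on a nitrogen on an aromatic ring therefore reads as a 1.8-fold higher number from compound 2 to compound 1 (0.24 log units; within the scatter), and on this read-out the two numbers cannot be placed in order. In this assay compound 3 gives 220 nM, the lowest of the three numbers; compound 2 stands nearest, and compound 1 furthest, with both gaps beyond the scatter.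

Compound 4 differs from compound 3 by 3,4-dichlorophenyl in place of 3,5-dichlorophenyl on a nitrogen on an aromatic ring. The place description is the same word for word as for the change from compound 2 to compound 1, so this is the same change, met twice in the set. The expected step is a 1.8-fold higher number from compound 3 to compound 4 (0.26 log units; within the scatter), a small movement, because a 1.8-fold higher number from compound 2 to compound 1 (0.24 log units; within the scatter) stayed within the scatter on the other core. On that basis compound 4 is expected to give about 400 nM in this assay, with the likely range running from 200 nM to 800 nM. Whether the second core carries the change the same way rests on a single precedent.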

Compound 4, half-maximal inhibitory concentration: 260 nM
Compound 4: the middle estimate sits 1.5-fold (0.19 log units) above what was measured; measured number inside the range.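

In this assay the swap of 3,5-dichlorophenyl for 3,4-dichlorophenyl on the second core reads as a 1.2-fold higher number from compound 3 to compound 4 (0.07 log units; within the scatter), so the two numbers cannot be placed in order. Set beside the earlier step, the change carries across the two cores with no difference that can be told apart: the same change on two cores in this assay, a 1.8-fold higher number (0.24 log units; within the scatter) from compound 2 to compound 1 and a 1.2-fold higher number (0.07 log units; within the scatter) from compound 3 to compound 4, 1.5-fold (0.17 log units) apart, within the scatter of two such steps. This shows only that, on these two cores and on this read-out, moving from one dichlorophenyl pattern to the other leaves the number within the scatter; it does not show that either pattern is better, that the change would stay this small on a further core, or that it would behave the same way on another read-out.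

The compounds shown carry only dichlorophenyl groups on that nitrogen, so it remains open how a 3-chlorophenyl, a 3,4-difluorophenyl or a pyridyl group would read there. Also open is which feature separates the two cores, since no pair shown differs in that feature alone, and whether a methoxy group on the phenyl of the amide side chain matters on its own.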